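Two Halobenzyl Ethers Guide a Nitrobenzyl Prediction

This account rests on a few compounds, and the source may have more. Where it says the series, first, only, none or still open, it means among the compounds named here.

Compound 1 `C#CCOc1ccc2c(=O)c(-c3cc(OC)c(OC)cc3OC)coc2c1` carries a propargyloxy group on the shared core. In a functional assay on HCT-116 cells (Homo sapiens) for antiproliferative activity, read by MTT assay, with a stated time of 24 h (a lower number here means a stronger inhibitor, a higher number a weaker inhibitor), compound 1 gives 8050 nM, the highest number among the three measured compounds, with compound 3 nearest and compound 2 furthest away. Compound 2 `COc1cc(OC)c(-c2coc3cc(OCc4ccc(F)cc4)ccc3c2=O)cc1OC` gives 950 nM in this assay, and compound 3 `COc1cc(OC)c(-c2coc3cc(OCc4ccc(Br)cc4)ccc3c2=O)cc1OC` gives 1980 nM. The steps out of compound 1 read an 8.5-fold lower number from compound 1 to compound 2 (0.93 log units; beyond the scatter) and a 4.1-fold lower number from compound 1 to compound 3 (0.61 log units; beyond the scatter), and between the two benzyl ethers the step is a 2.1-fold higher number from compound 2 to compound 3 (0.32 log units; beyond the scatter).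

Compound 4 `COc1cc(OC)c(-c2coc3cc(OCc4ccc([N+](=O)[O-])cc4)ccc3c2=O)cc1OC` has not yet been measured. Its difference from compound 1 is 4-nitrophenyl in place of ethynyl on a saturated chain carbon bound to an oxygen on an aromatic ring. The steps from compound 1 to compound 2 and from compound 1 to compound 3 both exchange ethynyl for a substituted phenyl at this same place, and both lowered the number beyond the scatter, though by modest amounts. Going by the values given here, no measured step compares a 4-nitrophenyl with a 4-fluorophenyl or 4-bromophenyl, so the size is taken from those two steps alone. Compound 4 is therefore expected to show a lower number than compound 1, by a step estimated at a 5.4-fold lower number from compound 1 to compound 4 (0.73 log units; beyond the scatter). The estimate for compound 4 in this assay is 1500 nM, with a range from 500 nM to 4500 nM.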

Compound 4, half-maximal inhibitory concentration: > 10000 nM
Compound 4 was reported as a limit; the forecaster's own chance of this, stated with the estimate: 5%; at least 6.6-fold (0.82 log units) between middle value and limit.
By their numbers in this assay, from the lowest: compound 2; then compound 3; then compound 1. At a limit, above all of these: compound 4.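

In this assay compound 4 stands only as a limit, not as a number: the limit of > 10000 nM in this assay, at which 1 of the 4 values shown sits. The earlier compounds shown here suggested that a substituted phenyl in place of ethynyl at this place lowers the number, yet the nitro compound does not follow them, and the step out of the propargyl ether now reads an at least 1.2-fold higher number from compound 1 to compound 4 (0.09 log units; that floor lies within the scatter), so the exchange of ethynyl for a substituted phenyl does not lower the number for every substituent, with compound 2 and compound 3 on one side and compound 4 against them. What decides the outcome here is the group on the aromatic carbon of the benzyl ether rather than the presence of the phenyl alone, since nitro in place of bromo gives an at least 5.0-fold higher number from compound 3 to compound 4 (0.70 log units; beyond the scatter) and nitro in place of fluoro gives an at least 10-fold higher number from compound 2 to compound 4 (1.02 log units; beyond the scatter), both larger than the step that separates the two halogens.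

As far as these compounds go, how far compound 4 lies past its limit stays open. Also open, from the compounds shown here alone, is whether an amine, a carboxylic acid or a chloro group on that aromatic carbon would stay with the halobenzyl ethers or go the way of the nitro group.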